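The compounds below may be only part of what the source reports. "The series", "measured", "known", "first", "only" and "open" are said of these compounds alone.

Compound 2 `ClCc1ccc(Cn2cnc3ncnc(Cl)c32)cc1` carries a chloromethylbenzyl group on the purine-like core shared by the set. In a functional assay on SW-620 cells (Homo sapiens) for cytotoxicity, read by sulforhodamine B assay, with a stated time of 48 h (a lower number here means a stronger inhibitor of growth, a higher number a weaker inhibitor of growth), compound 2 gives 7240 nM, the lowest of the two numbers recorded so far. Within the data shown here, the only other measured compound is compound 1 `ClCc1ccc(Cn2cnc3c(Cl)nc(Cl)nc32)cc1`, which in this assay gives 17400 nM; compound 1 differs from compound 2 in more than one place, so their values are simply set side by side, with compound 1 sitting at the higher number by a margin beyond the scatter.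

Compound 3 `ClCc1ccc(Cn2cnc3nc(Cl)nc(Cl)c32)cc1` has not yet been measured. It differs from compound 2 by chloro in place of hydrogen on an aromatic carbon, on an aromatic carbon of a six-membered aromatic ring with two nitrogen atoms, between two ring nitrogen atoms. Since compound 1, which also carries two chloro groups, gives 17400 nM, a modest step toward a weaker inhibitor of growth is expected for compound 3, a 1.4-fold higher number from compound 2 to compound 3 (0.14 log units; within the scatter). Compound 3 is accordingly estimated at 10000 nM, within a range from 4000 nM to 30000 nM.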

Compound 3, concentration for total growth inhibition: 28800 nM
The estimate for compound 3 lay 2.9-fold (0.46 log units) below the measured number; the measured number falls inside the stated range.
By their numbers in this assay, from the lowest: compound 2; then compounds 1 and 3 (each within the scatter of the next).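

In this assay placing chloro in place of hydrogen on an aromatic carbon, between two ring nitrogen atoms, gives a 4.0-fold higher number from compound 2 to compound 3 (0.60 log units; beyond the scatter) and so a weaker inhibitor of growth. This is the first change in one place among the compounds shown, and it shows that at this position, meta to a chloro group, hydrogen goes with the stronger inhibition of growth of the two groups compared. No measurement available here bears on why the step goes this way. Since only hydrogen and chloro are shown at this position, it stays open whether an amine, a methoxy group or a methyl group would give a number nearer to that of compound 2 or of compound 3. Going by these compounds, it also stays open whether the same step would appear if the chloro group already on the ring were replaced by an amine.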